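The compounds below may be only part of what the source reports. "The series", "measured", "known", "first", "only" and "open" are said of these compounds alone.

Measured compounds: compound 1 `CN(C)c1ccc(C(=O)Nc2cccc(NC(=O)COc3ccc4c(c3)NC(=O)CC4)c2)cc1` gives 3140 nM in an assay on isolated protein for inhibition of Rho-associated protein kinase 2 (Homo sapiens), read by scintillation counting, radiometric assay and 33P incorporation, with a stated time of 40 min, in the presence of a further agent that is not named here; a higher number here means a weaker inhibitor, a lower number a stronger inhibitor; compound 2 `CN(C)c1ccc(C(=O)Nc2cccc(NC(=O)COc3ccc4c(c3)CCC(=O)N4)c2)cc1` gives 9970 nM in this assay.

Going by the values given here, compound 2 holds the higher of the two numbers so far, the only measured step being a 3.2-fold higher number from compound 1 to compound 2 (0.50 log units; beyond the scatter). Compound 3 `COc1cccc(OCC(=O)Nc2cccc(NC(=O)c3ccc(N(C)C)cc3)c2)c1` differs from compound 2 by a group of 8 heavy atoms (7 carbon, 1 oxygen; one six-membered aromatic ring of carbon only) in place of a group of 11 heavy atoms (9 carbon, 1 nitrogen, 1 oxygen; one six-membered non-aromatic ring with 1 hetero atom, one six-membered aromatic ring of carbon only), on an oxygen on a saturated carbon. Among the compounds with values here, the single measured step bears on this change only loosely: it too sits on the oxygen on the saturated carbon, but it exchanges one group for another of the same count, whereas here the group entering is smaller and carries no hydrogen-bond donor. The measured step was modest and went upward; the step to compound 3 is expected to go in the same direction, larger rather than smaller, though with wide uncertainty. Compound 3 is therefore estimated at 18000 nM in this assay, within 5000 nM to 70000 nM, a step of a 1.8-fold higher number from compound 2 to compound 3 (0.26 log units; within the scatter).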

Compound 3, half-maximal inhibitory concentration: 5740 nM
Compound 3: middle estimate off by 3.1-fold (0.50 log units), on the high side; low and high end bracket the measured number.
By their numbers in this assay, from the lowest: compounds 1, 3 and 2 (each within the scatter of the next, the first and the last beyond it).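

In this assay, the 3-methoxyphenyl group on the oxygen on a saturated carbon gives a 1.7-fold lower number from compound 2 to compound 3 (0.24 log units; within the scatter) and a 1.8-fold higher number from compound 1 to compound 3 (0.26 log units; within the scatter). This position therefore takes a group with one aromatic ring, no non-aromatic ring and 0 hydrogen-bond donors, and the result cannot be told apart from either of the two larger groups, although those two differ from each other beyond the scatter. Nothing measured here accounts for this result.

The compounds shown leave open whether a plain phenyl, a 3-aminophenyl or a phenyl carrying a carboxylic acid on the same oxygen would move the number beyond the scatter. As far as these compounds go, all three compounds share the rest of the core, so the effect of any change elsewhere also remains open.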